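This account rests on a few compounds, and the source may have more. Where it says the series, first, only, none or still open, it means among the compounds named here.

Compound 3 `Cc1cnccc1-c1cc(F)cc(-n2nnc(-c3ccccn3)n2)c1` belongs to a small set built on one shared core, in which only the group on the aromatic carbon meta to the fluoro group is changed. In a functional assay for antagonist activity at metabotropic glutamate receptor 5 (Rattus norvegicus) (a higher number here means a weaker inhibitor, a lower number a stronger inhibitor), compound 3 gives 63 nM. Compound 1 `Nc1ccccc1-c1cc(F)cc(-n2nnc(-c3ccccn3)n2)c1` carries a 2-aminophenyl group at that position and in this assay gives 8 nM; compound 2 `Fc1cc(-c2ccccn2)cc(-n2nnc(-c3ccccn3)n2)c1` carries a pyridin-2-yl group and gives 39 nM. Among the three, compound 3 has the highest number: its gap to compound 2 lies within the scatter, while its gap to compound 1 lies beyond it.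

Compound 4 `Cc1ncccc1-c1cc(F)cc(-n2nnc(-c3ccccn3)n2)c1` differs from compound 3 in one place only: 2-methylpyridin-3-yl in place of 3-methylpyridin-4-yl on an aromatic carbon.

Two of the measured steps, a 4.9-fold higher number from compound 1 to compound 2 (0.69 log units; beyond the scatter) and a 7.9-fold higher number from compound 1 to compound 3 (0.90 log units; beyond the scatter), show that either pyridyl variant in place of the 2-aminophenyl group gives a modestly higher number. The step that most resembles the present change, a 1.6-fold higher number from compound 2 to compound 3 (0.21 log units; within the scatter), exchanges one pyridyl group for another and stays within the scatter. Nothing in the data distinguishes a 2-methylpyridin-3-yl from a 3-methylpyridin-4-yl at this position. Compound 4 is therefore expected to show a step no larger than the scatter, a 1.1-fold higher number from compound 3 to compound 4 (0.05 log units; within the scatter), in no firm direction. The expected value for compound 4 is 70 nM, between 25 nM and 200 nM.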

Compound 4, half-maximal inhibitory concentration: 41 nM
Compound 4: middle estimate off by 1.7-fold (0.23 log units), on the high side; low and high end bracket the measured number.
By their numbers in this assay, from the lowest: compound 1; then compounds 2, 4 and 3 (each within the scatter of the next).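

The exchange of 3-methylpyridin-4-yl for 2-methylpyridin-3-yl, which keeps the same atoms and counts, gives a 1.5-fold lower number from compound 3 to compound 4 (0.19 log units; within the scatter), and the comparison with the unmethylated pyridyl group gives a 1.1-fold higher number from compound 2 to compound 4 (0.02 log units; within the scatter); in this assay, compound 2, compound 3 and compound 4 therefore form a set of three pyridyl variants with no separation between any two of them. A third pyridyl attachment also stays apart from the 2-aminophenyl group, with a 5.1-fold higher number from compound 1 to compound 4 (0.71 log units; beyond the scatter), so compound 1 alone has steps to all the others that are printed as beyond the scatter, and none of the three pyridyl compounds goes against this within so small a set. No measurement here bears on the reason for either the flat pyridyl set or the separate place of compound 1.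

The compounds shown leave open whether the lower number of compound 1 depends on its amine or on its phenyl ring, a question that a plain phenyl group or a 2-aminopyridin-3-yl group at this position would address. They also leave open whether the flat pattern would hold for a pyridyl group carrying a methoxy group or a longer chain such as ethyl in place of the methyl.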